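Collapsing the bis-urea of compound 3 to a single fluorophenyl urea

The compounds below may be only part of what the source reports. "The series", "measured", "known", "first", "only" and "open" are said of these compounds alone.

Compound 3 `COc1cc(NC(C)CCCNC(=O)NNC(=O)Nc2cccc(Cl)c2)c2ncccc2c1` gives 27000 nM in a functional assay on L1210 cells (Mus musculus) for inhibition, read by MTT assay, with a stated time of 72 h (on this read-out higher numbers stand for weaker inhibition and lower numbers for stronger inhibition), the lowest of the three numbers. Compound 1 `COc1cc(NC(C)CCCNC(=O)NNC(=O)Nc2cccc(F)c2)c2ncccc2c1` gives 108000 nM and compound 2 `COc1cc(NC(C)CCCNC(=O)NNC(=O)Nc2ccc(O)cc2)c2ncccc2c1` gives 95000 nM; the step of a 4.0-fold lower number from compound 1 to compound 3 (0.60 log units; beyond the scatter) and the step of a 3.5-fold lower number from compound 2 to compound 3 (0.55 log units; beyond the scatter) set compound 3 apart. Compound 4 `COc1cc(NC(C)CCCNC(=O)Nc2cccc(F)c2)c2ncccc2c1` differs from compound 3 by 3-fluorophenyl in place of ((3-chlorophenyl)carbamoyl)amino on an amide-type nitrogen. Going by the values given here, no measured step removes this unit, but compound 4 carries the same 3-fluorophenyl as compound 1, and the step of a 4.0-fold lower number from compound 1 to compound 3 (0.60 log units; beyond the scatter) shows chloro lowering the number modestly. Compound 4 is therefore expected to move back toward compound 1, a step of a 3.0-fold higher number from compound 3 to compound 4 (0.47 log units; beyond the scatter) in this assay. Compound 4 is estimated at 80000 nM, within 25000 nM to 250000 nM.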

Compound 4, half-maximal inhibitory concentration: 19000 nM
Compound 4: middle estimate off by 4.2-fold (0.62 log units), on the high side; the measured number lies below the stated range.
By their numbers in this assay, from the lowest: compounds 4 and 3 (each within the scatter of the next); then compounds 2 and 1 (each within the scatter of the next).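

In this assay, 3-fluorophenyl in place of ((3-chlorophenyl)carbamoyl)amino on the amide-type nitrogen gives a 1.4-fold lower number from compound 3 to compound 4 (0.15 log units; within the scatter), so compound 3 keeps no measurable edge from the larger unit. Against the other two larger units, the same exchange gives a 5.0-fold lower number from compound 2 to compound 4 (0.70 log units; beyond the scatter) and a 5.7-fold lower number from compound 1 to compound 4 (0.75 log units; beyond the scatter), which shows that the single urea does not share the higher numbers of those compounds. No supporting measurement explains these results.

From the compounds shown here alone, what a 3-chlorophenyl, a 4-aminophenyl or a 3-carboxyphenyl on this nitrogen would give in the single urea remains open.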